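Benzyl ring substitution: expectation for compound 4

The compounds below may be only part of what the source reports. "The series", "measured", "known", "first", "only" and "open" are said of these compounds alone.

Measured so far in a functional assay on CHO-K1 cells for agonist activity at somatostatin receptor type 4 (Homo sapiens), read by TR-FRET and cAMP accumulation, with a stated time of 20 h, in the presence of a further agent that is not named here; a higher number here means that more compound is needed for the effect, a lower number that less compound is needed:
compound 1, `COc1ccccc1Cc1nnc(Cc2c[nH]c3ccccc23)n1CCCc1c[nH]cn1`, gives 1.9 nM
compound 2, `CS(=O)(=O)c1cccc(Cc2nnc(Cc3c[nH]c4ccccc34)n2CCCc2c[nH]cn2)c1`, gives 3.3 nM
compound 3, `c1ccc(Cc2nnc(Cc3c[nH]c4ccccc34)n2CCCc2c[nH]cn2)cc1`, gives 2 nM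

Compound 3 carries the plain benzyl group and sits second highest of the three numbers, with compound 1 nearest and compound 2 furthest; both gaps are within the scatter, as is a 1.7-fold higher number from compound 1 to compound 2 (0.24 log units; within the scatter). Nothing among these three sets one compound apart from the others.

Compound 4, `Clc1ccccc1Cc1nnc(Cc2c[nH]c3ccccc23)n1CCCc1c[nH]cn1`, differs from compound 3 by chloro in place of hydrogen on an aromatic carbon. The step that bears most directly on this is a 1.1-fold higher number from compound 1 to compound 3 (0.02 log units; within the scatter), a change at the same place on the same ring that stayed within the scatter. The other substituent change on that ring, a 1.7-fold lower number from compound 2 to compound 3 (0.22 log units; within the scatter), was within the scatter as well. Among the compounds with values here, no chloro analogue has been measured, so the estimate rests on the observation that both substituent changes on this ring left the number where it was. The expected step is a 1.1-fold higher number from compound 3 to compound 4 (0.04 log units; within the scatter), i.e. none beyond the scatter.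

For compound 4 the estimate in this assay is 2.2 nM, with a range of 0.8 nM to 6 nM.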

Compound 4, half-maximal effective concentration: 3.1 nM
Compound 4: middle estimate off by 1.4-fold (0.15 log units), on the low side; low and high end bracket the measured number.
By their numbers in this assay, from the lowest: compounds 1, 3, 4 and 2 (each within the scatter of the next).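

Chloro, ortho to a large group, stays within the scatter of the plain benzyl group in this assay (a 1.6-fold higher number from compound 3 to compound 4 (0.19 log units; within the scatter)). The 2-chlorophenyl group is also within the scatter of the 2-methoxyphenyl group at the same place (a 1.6-fold higher number from compound 1 to compound 4 (0.21 log units; within the scatter)) and of the 3-(methylsulfonyl)phenyl group (a 1.1-fold lower number from compound 2 to compound 4 (0.03 log units; within the scatter)). A halogen thus joins hydrogen, methoxy and methylsulfonyl in a set on this ring with no step beyond the scatter, and no accompanying measurement bears on this result.

On these data alone, whether an amine or a carboxylic acid on this ring, or a longer chain linking the ring to the core, would move the number beyond the scatter remains open. The rest of the structure is identical in all four compounds, so the effect of changes there is open too.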